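Working notes: aryl in place of chain on compound 1

The source may report more compounds than this note shows. Statements on the series, on what has been measured and on what is new or still open speak of the compounds shown alone.

Measured in an assay on CHO-K1 cells for displacement of a labelled ligand from adenosine receptor A1 (Homo sapiens), read by scintillation counting, with a stated time of 60 min; a higher number here means a weaker inhibitor, a lower number a stronger inhibitor:
compound 1, `CCCCC/C=C/C=C/C=N/Nc1nc(N)c2ncn([C@@H]3O[C@H](CO)[C@@H](O)[C@H]3O)c2n1` — 2 nM
compound 2, `Nc1nc(N/N=C/c2ccc3ncccc3c2)nc2c1ncn2[C@@H]1O[C@H](CO)[C@@H](O)[C@H]1O` — 9.8 nM
compound 3, `Nc1nc(N/N=C/C2CCCC2)nc2c1ncn2[C@@H]1O[C@H](CO)[C@@H](O)[C@H]1O` — 5.6 nM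

Compound 1 gives the lowest number of the three. Its nearest neighbour is compound 3, reached by a 2.8-fold higher number from compound 1 to compound 3 (0.45 log units; beyond the scatter); the furthest is compound 2, reached by a 4.9-fold higher number from compound 1 to compound 2 (0.69 log units; beyond the scatter). Between the two ring-bearing compounds the gap is a 1.8-fold lower number from compound 2 to compound 3 (0.24 log units; within the scatter), so they cannot be ordered against each other.

Compound 4, `N#Cc1ccc(/C=N/Nc2nc(N)c3ncn([C@@H]4O[C@H](CO)[C@@H](O)[C@H]4O)c3n2)cc1`, is the next compound for this assay. It differs from compound 1 in one place: a group of 8 heavy atoms (7 carbon, 1 nitrogen; one six-membered aromatic ring of carbon only) in place of a group of 9 heavy atoms (9 carbon; no ring), on a carbon with a double bond to nitrogen.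

Both steps away from compound 1 bear on this change. Each of them replaces the chain of compound 1 with a ring on the carbon with a double bond to nitrogen, and each raises the number by a modest amount beyond the scatter. The closer analogy is compound 2, where an aromatic ring enters; compound 3, with a non-aromatic ring, gives the smaller rise. A rise of similar size is therefore expected for compound 4, in the direction of a weaker inhibitor, as a 4.0-fold higher number from compound 1 to compound 4 (0.60 log units; beyond the scatter).

For compound 4 the expected value in this assay is 8 nM, with a range from 3 nM to 25 nM.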

Compound 4, inhibition constant: 4.1 nM
For compound 4 the middle estimate is 2.0-fold (0.29 log units) above the measured one; measured number inside the range.
By their numbers in this assay, from the lowest: compound 1; then compounds 4, 3 and 2 (each within the scatter of the next, the first and the last beyond it).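

Working from this assay, compound 4 extends the pattern: with a 2.1-fold higher number from compound 1 to compound 4 (0.31 log units; beyond the scatter), all three ring-bearing compounds now give higher numbers than the chain of compound 1, and none goes against this. The ring groups are not all equivalent at this carbon with a double bond to nitrogen, as 4-cyanophenyl and quinolin-6-yl are separated by a 2.4-fold lower number from compound 2 to compound 4 (0.38 log units; beyond the scatter), whereas 4-cyanophenyl and cyclopentyl cannot be ordered, with a 1.4-fold lower number from compound 3 to compound 4 (0.14 log units; within the scatter), so an aromatic ring as such does not set compound 4 apart from compound 3. No measurement at hand accounts for any of these steps.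

From the compounds shown here alone, the part played by the nitrile remains open: a plain phenyl, or a phenyl ring carrying an amine or a carboxylic acid in its place, would separate the contribution of that group from the contribution of the ring. The chain of compound 1 has double bonds. A fully saturated chain on the same carbon has not been measured here.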